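Removing a Second Chloro Group: From Compound 2 to Compound 4

This account rests on a few compounds, and the source may have more. Where it says the series, first, only, none or still open, it means among the compounds named here.

Of the compounds shown here, three have so far been tested in a functional assay on SF-539 cells (Homo sapiens) for cytotoxicity, read by sulforhodamine B assay, with a stated time of 48 h; a higher number here means a weaker inhibitor of growth, a lower number a stronger inhibitor of growth. Compound 1 `ClCc1ccc(Cn2cnc3c(Cl)ncnc32)cc1` gives 1170 nM, compound 3 `ClCc1ccccc1Cn1cnc2c(Cl)ncnc21` gives 24000 nM, and compound 2 `ClCc1cccc(Cn2cnc3c(Cl)nc(Cl)nc32)c1` gives 14100 nM. Among these three numbers compound 2 holds the second highest; its nearest neighbour is compound 3, whose value lies within the scatter of it, while compound 1 sits far lower, beyond the scatter. Compound 4 `ClCc1cccc(Cn2cnc3c(Cl)ncnc32)c1` has not yet been measured. It differs from compound 2 in a single place: hydrogen in place of chloro on an aromatic carbon. Among the compounds with values here, no measured pair shows this same change, so the size of the step in this assay is uncertain; a modest move toward a lower number is expected, though a result within the scatter would not surprise. Compound 4 is therefore expected to give 8000 nM, somewhere between 2000 nM and 30000 nM, which means an expected step of a 1.8-fold lower number from compound 2 to compound 4 (0.25 log units; within the scatter).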

Compound 4, concentration for total growth inhibition: 35500 nM
Compound 4: the middle estimate sits 4.4-fold (0.65 log units) below what was measured, and the stated range ends below it.
By their numbers in this assay, from the lowest: compound 1; then compounds 2, 3 and 4 (each within the scatter of the next, the first and the last beyond it).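

In this assay, putting hydrogen in place of chloro on the aromatic carbon between two ring nitrogen atoms gives a 2.5-fold higher number from compound 2 to compound 4 (0.40 log units; beyond the scatter). The earlier compounds shown here held no pair that isolated this change. This pair shows that the chloro group at this position goes with stronger growth inhibition, although the step is modest and comes from a single pair.

On these data alone, whether an amine or a methoxy group on this same carbon would give a lower or a higher number stays open. Nothing shown explains why removing the chloro group weakens growth inhibition.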